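The source may report more compounds than this note shows. Statements on the series, on what has been measured and on what is new or still open speak of the compounds shown alone.

Compound 1 `C[C@]1(CN2CCc3nc(-c4ccccc4)ccc3C2)Cn2cc([N+](=O)[O-])nc2O1` gives > 32 ug/mL in an ADME assay on Vero cells (Chlorocebus sabaeus) for cytotoxicity, read by MTT assay, with a stated time of 72 h (a higher number here means that more compound is tolerated, a lower number that less compound is tolerated), which is a limit of the assay. Compound 2 `C[C@]1(CN2CCc3nc(-c4cc(F)cc(F)c4)ccc3C2)Cn2cc([N+](=O)[O-])nc2O1` gives > 32 ug/mL, likewise a limit. Compound 3 `C[C@]1(CN2CCc3nc(-c4cc(F)ccc4F)ccc3C2)Cn2cc([N+](=O)[O-])nc2O1` gives > 32 ug/mL, again a limit.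

Compound 3 therefore stands at the limit of > 32 ug/mL in this assay, at which 3 of the 3 values shown sit, and cannot be placed against the other two. Compound 4 `C[C@]1(CN2CCc3nc(-c4cc(F)c(F)c(F)c4)ccc3C2)Cn2cc([N+](=O)[O-])nc2O1` carries 3,4,5-trifluorophenyl in place of 2,5-difluorophenyl on an aromatic carbon. Among the compounds with values here, the steps that bear on this change are a step that the two limits leave unreadable from compound 1 to compound 3 and a step that the two limits leave unreadable from compound 2 to compound 3, neither readable in size. Within the data shown here, nothing among the measured compounds points to a change beyond the scatter, so the expected step that the limit leaves unreadable from compound 3 to compound 4 is none beyond it. Compound 4 is estimated at 45 ug/mL, between 25 ug/mL and 90 ug/mL.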

Compound 4, half-maximal cytotoxic concentration: > 32 ug/mL
Compound 4: no number, only a limit; the forecaster's own chance of this, stated with the estimate: 85%; the middle value lies beyond the limit too.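

Compound 4 also gives only a limit, so no step among compound 1, compound 2, compound 3 and compound 4 can be read in this assay: the limit of > 32 ug/mL in this assay, at which 4 of the 4 values shown sit.

The compounds shown leave open whether these four differ at all in this assay, and by how much.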